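This account rests on a few compounds, and the source may have more. Where it says the series, first, only, none or still open, it means among the compounds named here.

Measured so far in an assay on isolated protein for inhibition of legumain (Mus musculus), read by fluorescence, with stated times of 30 s and 2.5 h; on this read-out lower numbers stand for stronger inhibition and higher numbers for weaker inhibition:
Compound 1 `C/C=C(\NC(C)=O)C(=O)N1CCC[C@H]1C(=O)NN(CC(N)=O)C(=O)/C=C/C(=O)OCC` gives 141 nM.
Compound 2 `CCOC(=O)/C=C/C(=O)N(CC(N)=O)NC(=O)[C@@H]1CCCN1C(=O)C(NC(C)=O)=C(C)C` gives 148 nM.
Compound 3 `C#CC[C@H](NC(C)=O)C(=O)N1CCC[C@H]1C(=O)NN(CC(N)=O)C(=O)/C=C/C(=O)OCC` gives 17 nM.

Compound 3 stands lowest of the three: an 8.3-fold lower number from compound 1 to compound 3 (0.92 log units; beyond the scatter) and an 8.7-fold lower number from compound 2 to compound 3 (0.94 log units; beyond the scatter), whereas a 1.0-fold higher number from compound 1 to compound 2 (0.02 log units; within the scatter). Compound 4 `CCOC(=O)/C=C/C(=O)N(CC(N)=O)NC(=O)[C@@H]1CCCN1C(=O)c1cccc(NC(C)=O)c1` differs from compound 3 at the same carbonyl carbon: a group of 10 heavy atoms (8 carbon, 1 nitrogen, 1 oxygen; one six-membered aromatic ring of carbon only) in place of a group of 8 heavy atoms (6 carbon, 1 nitrogen, 1 oxygen; no ring), on a carbonyl carbon. Going by the values given here, no measured step exchanges a chain for an aromatic ring, but the two steps into compound 3 show that this position shifts this assay by a modest yet clear amount. Since the gain into compound 3 came with an 8.3-fold lower number from compound 1 to compound 3 (0.92 log units; beyond the scatter), compound 4 is expected to give most of it back, an 8.8-fold higher number from compound 3 to compound 4 (0.95 log units; beyond the scatter). Compound 4 is estimated at 150 nM, within 40 nM to 600 nM.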

Compound 4, half-maximal inhibitory concentration: > 1000 nM
Compound 4 ended at the assay's limit; the forecaster's own chance of this, stated with the estimate: 5%; at least 6.6-fold (0.82 log units) between middle value and limit.
By their numbers in this assay, from the lowest: compound 3; then compounds 1 and 2 (each within the scatter of the next). At a limit, above all of these: compound 4.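

The value of compound 4 in this assay is a limit and not a number: the limit of > 1000 nM in this assay, at which 1 of the 4 values shown sits.

Even so, replacing the open chains on this carbonyl carbon with 3-acetamidophenyl produces the largest step seen at this position, an at least 58-fold higher number from compound 3 to compound 4 (1.76 log units; beyond the scatter), and it also separates compound 4 from the two weaker chain compounds, an at least 6.7-fold higher number from compound 2 to compound 4 (0.82 log units; beyond the scatter) and an at least 7.0-fold higher number from compound 1 to compound 4 (0.85 log units; beyond the scatter). This position therefore does more than shift the read-out modestly among chains: a large loss is possible here.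

From the compounds shown here alone, how far compound 4 lies past the limit stays open. With only this ring shown, it is also open whether the loss follows from the phenyl ring itself or from its acetamido group, which an unsubstituted phenyl or a phenyl bearing an amine could help separate.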